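Moving the pyridine nitrogen on a weak antiproliferative core

This account rests on a few compounds, and the source may have more. Where it says the series, first, only, none or still open, it means among the compounds named here.

Compound 1 `Cc1cn2c(/C=N/NC(=N)N)c(-c3cccnc3)nc2s1`: 15800 nM
Compound 2 `N=C(N)N/N=C/c1c(-c2cccnc2)nc2sc(Cl)cn12`: 15500 nM

In a functional assay on ovarian cells (Homo sapiens) for antiproliferative activity (on this read-out higher numbers stand for weaker inhibition of growth and lower numbers for stronger inhibition of growth), compound 1 gives 15800 nM, the highest of the two numbers; its nearest neighbour is compound 2, and the step of a 1.0-fold lower number from compound 1 to compound 2 (0.01 log units; within the scatter) lies within the scatter. Compound 3 `Cc1cn2c(/C=N/NC(=N)N)c(-c3ccccn3)nc2s1` differs from compound 1 by pyridin-2-yl in place of pyridin-3-yl on an aromatic carbon. For the measured compounds named here, no measured step bears on this change, since the only step known alters a different ring position. The number for compound 3 in this assay is therefore expected to stay near that of compound 1, with a 1.0-fold higher number from compound 1 to compound 3 (0.01 log units; within the scatter) as the estimated step, giving an estimate of 16000 nM, ranging from 5000 nM to 50000 nM.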

Compound 3, concentration for 50% growth inhibition: 17400 nM
Beside the measured number, compound 3's estimate is 1.1-fold (0.04 log units) below it; low and high end bracket the measured number.
By their numbers in this assay, from the lowest: compounds 2, 1 and 3 (each within the scatter of the next).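

Pyridin-2-yl in place of pyridin-3-yl gives a 1.1-fold higher number from compound 1 to compound 3 (0.04 log units; within the scatter) in this assay. For the compounds shown here, this is the first reading on the aromatic ring carried at this position of the shared core, and the two pyridine isomers read alike within the scatter. Placing the ring nitrogen of this group differently thus leaves the number where the methyl and chloro pair already sat.

On these data alone, whether pyridin-4-yl, a plain phenyl ring or a phenyl ring bearing an amine would leave the number in the same range stays open. Nothing in the data given explains the result.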